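Ring Swap on the Amide Chain of a Weak Inhibitor

The source may report more compounds than this note shows. Statements on the series, on what has been measured and on what is new or still open speak of the compounds shown alone.

Three compounds share one core and differ only in the saturated group on the amide nitrogen. Compound 1 `CC(=O)N1CCC(NC(=O)c2ccncc2Nc2cc(-c3ccc4ccn(C)c4c3)c3nccnc3c2)CC1` carries a 1-acetylpiperidin-4-yl group and gives 31300 nM in an assay on lysate for inhibition of 6-phosphofructo-2-kinase/fructose-2,6-bisphosphatase 3 (Homo sapiens), with stated times of 0.5 min and 45 min; on this read-out higher numbers stand for weaker inhibition and lower numbers for stronger inhibition. Compound 2 `CC(=O)N1CCCC(NC(=O)c2ccncc2Nc2cc(-c3ccc4ccn(C)c4c3)c3nccnc3c2)C1` carries the 1-acetylpiperidin-3-yl group and gives 13500 nM in this assay; the change from compound 1 to compound 2 gives a 2.3-fold lower number from compound 1 to compound 2 (0.37 log units; beyond the scatter). Compound 3 `CC(=O)N1CC(CNC(=O)c2ccncc2Nc2cc(-c3ccc4ccn(C)c4c3)c3nccnc3c2)C1` carries the (1-acetylazetidin-3-yl)methyl group, and in this assay compound 3 reaches only a limit of the assay, > 100000 nM. This places compound 3 at the weak end of the set, with an at least 3.1-fold higher number from compound 1 to compound 3 (0.50 log units; beyond the scatter) and an at least 7.4-fold higher number from compound 2 to compound 3 (0.86 log units; beyond the scatter); its number sits at the limit of > 100000 nM in this assay, at which 1 of the 3 values shown sits.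

Compound 4 `CN1CCC(CNC(=O)c2ccncc2Nc2cc(-c3ccc4ccn(C)c4c3)c3nccnc3c2)C1` is the next step: 1-methylpyrrolidin-3-yl in place of 1-acetylazetidin-3-yl on a saturated chain carbon bound to an amide-type nitrogen. Among the compounds with values here, none of the measured steps removes an acetyl group or changes a ring in this way, so they bear on it only by showing that the chain-linked group of compound 3 sits at the limit. The account expects a step of an at least 1.2-fold lower number from compound 3 to compound 4 (0.09 log units; that floor lies within the scatter) in this assay from compound 3 to compound 4 that is either none beyond the scatter or modest toward a lower number. The account therefore estimates compound 4 at 80000 nM in this assay, within a range from 20000 nM to 300000 nM.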

Compound 4, half-maximal inhibitory concentration: 24000 nM
Compound 4: the middle estimate sits 3.3-fold (0.52 log units) above what was measured; measured number inside the range.
By their numbers in this assay, from the lowest: compounds 2, 4 and 1 (each within the scatter of the next, the first and the last beyond it). At a limit, above all of these: compound 3.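

Exchanging the 1-acetylazetidin-3-yl group for 1-methylpyrrolidin-3-yl on a saturated chain carbon bound to an amide-type nitrogen gives an at least 4.1-fold lower number from compound 3 to compound 4 (0.61 log units; beyond the scatter), so a chain-linked group at this position need not sit at the limit in this assay. Compound 4 also shows that an acetyl group on the ring nitrogen is not required for a measurable value, since its comparisons with the two directly attached acetylpiperidines are a 1.8-fold higher number from compound 2 to compound 4 (0.25 log units; within the scatter) and a 1.3-fold lower number from compound 1 to compound 4 (0.12 log units; within the scatter), which leaves these three compounds inside the scatter of one another on those two steps. Compound 3 alone remains at a limit and not at a number, so the true size of its step to compound 4 stays unknown: the limit of > 100000 nM in this assay, at which 1 of the 4 values shown sits.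

The step from compound 3 to compound 4 changes the ring and the group on its nitrogen together, so the compounds shown cannot say how much of it belongs to either change. A (1-acetylpyrrolidin-3-yl)methyl or a (1-methylazetidin-3-yl)methyl group on the amide nitrogen would separate the two, and a 1-methylpiperidin-3-yl group would test the methyl group without the chain carbon.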